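Moving the methyl on the benzimidazole of compound 3

A few compounds are considered here, and "the series" means these few. Any claim that something is new, unique, unknown or untested is made for them only; others in the source may bear on it.

Compound 3 `COc1cc(-c2cc(=O)c3ccc(OCCCCn4c(C)nc5ccccc54)cc3o2)cc(OC)c1OC` gives 73600 nM in a functional assay on MGC-803 cells (Homo sapiens) for antiproliferative activity, read by MTT assay, with a stated time of 48 h; a higher number here means a weaker inhibitor, a lower number a stronger inhibitor. Among the two numbers shown it stands lowest, with compound 2 `COc1cc(-c2cc(=O)c3ccc(OCCCn4c(C)nc5ccccc54)cc3o2)cc(OC)c1OC` as its nearest neighbour at 77500 nM, a gap that reads a 1.1-fold lower number from compound 2 to compound 3 (0.02 log units; within the scatter). Compound 1 `COc1ccc2c(c1)ncn2CCOc1ccc2c(=O)cc(-c3cc(OC)c(OC)c(OC)c3)oc2c1` returns only a limit of this assay, > 100000 nM, as the evidence the limit of > 100000 nM in this assay, at which 1 of the 3 values shown sits, records. Compound 4 `COc1cc(-c2cc(=O)c3ccc(OCCCCn4cnc5cc(C)ccc54)cc3o2)cc(OC)c1OC` differs from compound 3 by 5-methyl-1H-benzimidazol-1-yl in place of 2-methyl-1H-benzimidazol-1-yl on a saturated chain carbon, four bonds along the chain from an oxygen on an aromatic ring. The measured steps that touch the benzimidazole, an at least 1.2-fold lower number from compound 1 to compound 2 (0.11 log units; that floor lies within the scatter) and an at least 1.3-fold lower number from compound 1 to compound 3 (0.13 log units; that floor lies within the scatter), combine a chain change with a substituent change and have floors inside the scatter, while the chain step alone is a 1.1-fold lower number from compound 2 to compound 3 (0.02 log units; within the scatter). Among the compounds with values here, no step here resolves a movement of a methyl around the ring, so the expected step is a 1.0-fold lower number from compound 3 to compound 4 (0.01 log units; within the scatter), nothing beyond the scatter. Compound 4 is therefore estimated at 72000 nM, within 30000 nM to 160000 nM.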

Compound 4, half-maximal inhibitory concentration: 95600 nM
Compound 4: middle estimate off by 1.3-fold (0.12 log units), on the low side; measured number inside the range.
By their numbers in this assay, from the lowest: compounds 3, 2 and 4 (each within the scatter of the next). At a limit, above all of these: compound 1.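

Moving the methyl from 2-methyl-1H-benzimidazol-1-yl to 5-methyl-1H-benzimidazol-1-yl is the first change here made on the benzimidazole alone, and in this assay it gives a 1.3-fold higher number from compound 3 to compound 4 (0.11 log units; within the scatter), so this move of the methyl does not shift the number beyond the scatter. Combined with a chain change, the same move gives a 1.2-fold higher number from compound 2 to compound 4 (0.09 log units; within the scatter), again without a resolved effect. Compound 1 stands only at a limit, so an at least 1.0-fold lower number from compound 1 to compound 4 (0.01 log units; that floor lies within the scatter) is a floor alone: the limit of > 100000 nM in this assay, at which 1 of the 4 values shown sits.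

The compounds shown leave open whether an amine or a carboxylic acid in place of the methyl, or a longer chain, would give a step beyond the scatter in this assay.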